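The compounds below may be only part of what the source reports. "The series", "measured", "known", "first", "only" and "open" are said of these compounds alone.

Measured compounds in this series:
compound 1 `C=CCn1ccc(N2C[C@H](CO)OC2=O)c1`, 350 nM
compound 2 `COC[C@H]1CN(c2ccn(C)c2)C(=O)O1`, 300 nM
compound 3 `Cn1ccc(N2C[C@H](CN=[N+]=[N-])OC2=O)c1`, 200 nM

In an assay for inhibition of Amine oxidase [flavin-containing] A (Bos taurus), read by fluorescence, with a stated time of 30 min (a lower number here means a stronger inhibitor, a higher number a weaker inhibitor), compound 3 holds the lowest of the three numbers, but its gaps to compound 2 and to compound 1 are both within the scatter, so the three stand as one group. Compound 4 `Cn1ccc(N2C[C@H](CN)OC2=O)c1` differs from compound 3 by amino in place of azido on a saturated chain carbon bound to a saturated ring carbon. Among the compounds with values here, the only measured step at the same position is a 1.5-fold lower number from compound 2 to compound 3 (0.18 log units; within the scatter), which lay within the scatter. Within the data shown here, no measured pair covers an exchange of azido for amino, and the three numbers seen so far spread little; a step beyond the scatter is therefore not expected. Compound 4 is estimated at 300 nM, range 110 nM to 850 nM, which means an expected step of a 1.5-fold higher number from compound 3 to compound 4 (0.18 log units; within the scatter).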

Compound 4, inhibition constant: 10 nM
Compound 4: middle estimate off by 30-fold (1.48 log units), on the high side; measured number outside the range, below it.
By their numbers in this assay, from the lowest: compound 4; then compounds 3, 2 and 1 (each within the scatter of the next).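

In this assay the position on a saturated chain carbon bound to a saturated ring carbon had looked flat, with methoxy and azido not separated (a 1.5-fold lower number from compound 2 to compound 3 (0.18 log units; within the scatter)). Amino shows that it is not: the series gives (a 20-fold lower number from compound 3 to compound 4 (1.30 log units; beyond the scatter)) and (a 30-fold lower number from compound 2 to compound 4 (1.48 log units; beyond the scatter)). Amino brings a hydrogen-bond donor that azido lacks, but nothing on hand ties the shift to that or to any other feature of the group. Open, going by these compounds, is whether a methylamino or acetamido group, or a longer chain ending in an amine, keeps this level.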